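Methyl on the amine nitrogen: compound 2 to compound 3

A few compounds are considered here, and "the series" means these few. Any claim that something is new, unique, unknown or untested is made for them only; others in the source may bear on it.

Compound 1, `COc1cccc(OC)c1[C@@H]1C[C@H](N(C)C)C(=O)N1Cc1ccc(OC(F)(F)F)cc1`: 8300 nM
Compound 2, `CN[C@@H]1C[C@@H](c2c(OC)cccc2OC)N(Cc2ccc(OC(F)(F)F)cc2)C1=O`: 5810 nM

In a functional assay on CHO cells for antagonist activity at Orexin receptor type 2 (Homo sapiens), read by FLIPR and calcium flux (on this read-out lower numbers stand for stronger inhibition and higher numbers for weaker inhibition), compound 2 gives 5810 nM, the lowest of the two numbers, and compound 1 gives 8300 nM, within the scatter of compound 2. Compound 3, `COc1cccc(OC)c1[C@@H]1C[C@@H](N(C)C)C(=O)N1Cc1ccc(OC(F)(F)F)cc1`, is not yet measured. It differs from compound 2 by methyl in place of hydrogen on an amine nitrogen. Among the measured compounds shown here, no measured pair shows this change, so the size of the step cannot be taken from a comparison; with both known values so close, no step beyond the scatter is expected. The estimate for compound 3 is 6500 nM, in the range 2000 nM to 20000 nM, a step of a 1.1-fold higher number from compound 2 to compound 3 (0.05 log units; within the scatter) that is expected to stay inside the scatter.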

Compound 3, half-maximal inhibitory concentration: > 10000 nM
Compound 3 gave a limit, no number; the forecaster's own chance of this, stated with the estimate: 10%; at least 1.5-fold (0.18 log units) between middle value and limit.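

Compound 3 gives only a limit in this assay, not a number: the limit of > 10000 nM in this assay, at which 1 of the 3 values shown sits. Methylamino to dimethylamino gives an at least 1.7-fold higher number from compound 2 to compound 3 (0.23 log units; that floor lies within the scatter), and changing one drawn stereocentre at a saturated ring carbon gives an at least 1.2-fold higher number from compound 1 to compound 3 (0.08 log units; that floor lies within the scatter). Both floors lie within the scatter, so neither step shows a real change, and the second is a clean test of configuration alone: the fact that compounds 1 and 3 differ only in the configuration as drawn.

From the compounds shown here alone, the true value of compound 3 stays open, so the real size of both steps cannot be read. Also open, going by these compounds, is how this position would respond to a primary amine or an ethyl group on the nitrogen.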